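Aryl for cyclopropyl on the ring amide nitrogen

The compounds below may be only part of what the source reports. "The series", "measured", "known", "first", "only" and "open" are said of these compounds alone.

Measured compounds:
compound 1 `O=C1COc2ccc(-c3cccc(NS(=O)(=O)c4ccc(F)cc4)c3)cc2N1C1CC1` — > 40000 nM
compound 2 `O=C1COc2ccc(-c3cnc4ccccc4c3)cc2N1c1ccc(Cl)cc1` — 32700 nM
compound 3 `COc1cccc(N2C(=O)COc3ccc(-c4ccc(O)cc4)cc32)c1` — 26100 nM

Of the compounds shown here, three sharing one core have been tested in a functional assay on HepG2 cells (Homo sapiens) for antiproliferative activity, read by MTT assay, with a stated time of 72 h; on this read-out lower numbers stand for stronger inhibition and higher numbers for weaker inhibition. Compound 1 gives only a limit, > 40000 nM, which is a boundary of this assay and not a number. Compound 2 gives 32700 nM in this assay. Compound 3 gives 26100 nM in this assay. Thus compound 1 stands at the limit where the values end, (the limit of > 40000 nM in this assay, at which 1 of the 3 values shown sits), while compound 2 and compound 3 carry aryl groups on the ring amide nitrogen and give finite values in this assay.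

Compound 4 `COc1ccc(N2C(=O)COc3ccc(-c4cccc(NS(=O)(=O)c5ccc(F)cc5)c4)cc32)cc1` has not yet been measured in this assay. It differs from compound 1 in one place: 4-methoxyphenyl in place of cyclopropyl on an amide-type nitrogen in a ring. For the measured compounds named here, no pair of measured compounds differs in a single place, so no measured step is at hand for this change. Compound 2, which carries an aryl group on the same nitrogen, gives 32700 nM in this assay. Compound 3, which also carries an aryl group on that nitrogen, gives 26100 nM in this assay. On the strength of these two values, the step from compound 1 to compound 4 is expected to go toward stronger inhibition in this assay, though its size is uncertain, as compound 1 gives only a limit. The expected step is an at least 1.6-fold lower number from compound 1 to compound 4 (0.20 log units; that floor lies within the scatter). Compound 4 is expected to give about 25000 nM in this assay, within 8000 nM to 60000 nM.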

Compound 4, half-maximal inhibitory concentration: 29800 nM
Estimate against measurement, compound 4: 1.2-fold (0.08 log units) below; the measured number falls inside the stated range.
By their numbers in this assay, from the lowest: compounds 3, 4 and 2 (each within the scatter of the next). At a limit, above all of these: compound 1.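

In this assay, for the compounds shown here, 4-methoxyphenyl in place of cyclopropyl on the amide-type nitrogen in a ring gives an at least 1.3-fold lower number from compound 1 to compound 4 (0.12 log units; that floor lies within the scatter), the first comparison at this position in which the rest of the molecule stays unchanged. Compound 1 gives > 40000 nM, a limit of the assay and not a number, so only a floor on this step can be read: the limit of > 40000 nM in this assay, at which 1 of the 4 values shown sits. The pair shows that this nitrogen can carry 4-methoxyphenyl and still give a finite value in this assay, but with a floor inside the scatter it does not establish a real gain in strength.

The compounds shown leave open what a plain phenyl, a 4-aminophenyl or a longer alkyl chain such as n-butyl on this nitrogen would give, so the methoxy group cannot be separated from the aromatic ring that carries it. They also leave open how large the step really is, and whether a change at this nitrogen would have the same effect with a different group at the other end of the shared core.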